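Bis-amide series: methoxymethyl in place of cyclobutyl

The source may report more compounds than this note shows. Statements on the series, on what has been measured and on what is new or still open speak of the compounds shown alone.

Measured in an in vitro functional assay on HEK293-A cells for antagonist activity at metabotropic glutamate receptor 5 (Rattus norvegicus), read by calcium flux; a lower number here means a stronger inhibitor, a higher number a weaker inhibitor:
compound 1, `COc1ccccc1C(=O)Nc1cccc(NC(=O)C2CCC2)c1`, gives > 30000 nM, a limit of the assay and not a number.
compound 2, `COCC(=O)Nc1cccc(NC(=O)c2ccccc2OC)c1`, gives > 30000 nM, a limit of the assay and not a number.
compound 3, `O=C(Nc1cccc(NC(=O)C2CCC2)c1)c1cccc(Cl)c1`, gives 5270 nM.

Compound 2 differs from compound 1 by methoxymethyl in place of cyclobutyl on a carbonyl carbon. The step that the two limits leave unreadable from compound 1 to compound 2 cannot be sized, because of the limit of > 30000 nM in this assay, at which 2 of the 3 values shown sit. Compound 3 differs from compound 1 by 3-chlorophenyl in place of 2-methoxyphenyl on a carbonyl carbon, and the step of an at least 5.6-fold lower number from compound 1 to compound 3 (0.75 log units; beyond the scatter) is the one readable movement in the set. Compound 4, `COCC(=O)Nc1cccc(NC(=O)c2cccc(Cl)c2)c1`, is not yet measured. It differs from compound 3 by methoxymethyl in place of cyclobutyl on a carbonyl carbon, the same change as that from compound 1 to compound 2, made on the same kind of carbonyl carbon. Since that earlier step is unreadable, there is no measured anchor for its size here. The expected step is a 1.5-fold higher number from compound 3 to compound 4 (0.18 log units; within the scatter), a guess of little change, held wide. Compound 4 is therefore estimated at 8000 nM, between 2500 nM and 30000 nM, with a real chance that only a limit is returned.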

Compound 4, half-maximal inhibitory concentration: > 30000 nM
Compound 4 ended at the assay's limit; the forecaster's own chance of this, stated with the estimate: 25%; at least 3.7-fold (0.57 log units) between middle value and limit.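

In this assay, methoxymethyl in place of cyclobutyl on a carbonyl carbon gives an at least 5.6-fold higher number from compound 3 to compound 4 (0.75 log units; beyond the scatter), so on the core of compound 3 the change weakens inhibition beyond the scatter. Compound 4 gives > 30000 nM, a limit of the assay and not a number, so the step has a lower bound but no known full size. The same change on the core of compound 1 cannot be read, so this result does not show whether the change has a similar size or even the same direction on both cores, because of a single shared limit: the limit of > 30000 nM in this assay, at which 3 of the 4 values shown sit.

The compounds shown leave open whether the loss on the core of compound 3 goes with the departure of the four-membered ring or with the arrival of the oxygen in the chain. Also open, on these data alone, is how a cyclopropyl group, a propyl chain or an amine would read on the same carbonyl carbon.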